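The source may hold more compounds than are shown below. What is called first, only, known or untested is meant among the compounds shown, and "the series" means these compounds.

Compound 1, `Cn1c(-c2ccc(C(=O)NC(C)(C)C)cc2)nnc1C1(c2ccc(Cl)cc2)CCC1`, was tested in an assay on isolated protein for inhibition of 11-beta-hydroxysteroid dehydrogenase type 2 (Homo sapiens); on this read-out higher numbers stand for weaker inhibition and lower numbers for stronger inhibition. In that assay compound 1 gave only a limit, > 4000 nM. Compound 2, `Cn1c(-c2ccc(-c3cccnc3)cc2Cl)nnc1C1(c2ccc(Cl)cc2)CCC1`, likewise gave only a limit in this assay, namely > 4000 nM. Everything measured so far therefore sits at the limit of > 4000 nM in this assay, at which 2 of the 2 values shown sit. Compound 3, `CCNC(=O)c1ccc(-c2nnc(C3(c4ccc(Cl)cc4)CCC3)n2C)cc1`, has not yet been measured. It differs from compound 1 by ethyl in place of tert-butyl on an amide-type nitrogen. Going by the values given here, no measured pair shows such a change, so the step that the limit leaves unreadable from compound 1 to compound 3 is expected to stay within the scatter, without a clear direction. Compound 3 is thus estimated at 6000 nM, within 2000 nM to 20000 nM.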

Compound 3, half-maximal inhibitory concentration: > 4000 nM
Compound 3 was reported as a limit (the forecaster's own chance of this, stated with the estimate: 70%); the middle value lies beyond the limit too.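

Compound 1 and compound 3 each gave only a limit, so no step between them can be read: the limit of > 4000 nM in this assay, at which 3 of the 3 values shown sit.

The compounds shown leave open how strongly any of them truly inhibits, and whether ethyl in place of tert-butyl changes that at all.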